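Adding a Trifluoromethyl Group to Compound 2

The source may report more compounds than this note shows. Statements on the series, on what has been measured and on what is new or still open speak of the compounds shown alone.

Measured so far:
- compound 1, `C=C(Br)C(=O)Nc1cccc(/C=C2\SC(=O)N(Cc3ccc(Cl)cc3)C2=O)c1`: 940 nM
- compound 2, `C=C(Br)C(=O)Nc1cccc(/C=C2\SC(=O)N(Cc3ccccc3)C2=O)c1`: 380 nM
- compound 3, `Nc1cccc(/C=C2\SC(=O)N(Cc3ccccc3)C2=O)c1`: 233000 nM

All three were tested in a functional assay on L1210 cells (Mus musculus) for cytotoxicity, read by cell counting, with a stated time of 2 days; on this read-out lower numbers stand for stronger inhibition and higher numbers for weaker inhibition. Compound 2 stands lowest of the three numbers in this assay, at 380 nM. Replacing chloro with hydrogen on the aromatic carbon gave a 2.5-fold lower number from compound 1 to compound 2 (0.39 log units; beyond the scatter), a modest step. Replacing the (1-bromoethenyl)carbonyl group on the ring nitrogen with hydrogen gave a 610-fold higher number from compound 2 to compound 3 (2.79 log units; beyond the scatter), a large step, so compound 3 at 233000 nM lies far behind the other two.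

Compound 4, `C=C(Br)C(=O)Nc1cccc(/C=C2\SC(=O)N(Cc3ccc(C(F)(F)F)cc3)C2=O)c1`, has not yet been measured. It differs from compound 2 by trifluoromethyl in place of hydrogen on an aromatic carbon, placed on an aromatic carbon of a six-membered aromatic ring of carbon only, para to a large group. Going by the values given here, the only measured step that bears on this spot is the one from compound 1 to compound 2, where the chloro group at this position was worth a 2.5-fold lower number from compound 1 to compound 2 (0.39 log units; beyond the scatter). Read in reverse, a group entering there costs a modest amount, and a trifluoromethyl group may be expected to behave in a similar way. Compound 4 is therefore expected to show a 2.6-fold higher number from compound 2 to compound 4 (0.42 log units; beyond the scatter), a modest rise in number rather than a large one. The estimate for compound 4 in this assay is 1000 nM, with a range from 300 nM to 3500 nM.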

Compound 4, half-maximal inhibitory concentration: 720 nM
For compound 4 the middle estimate is 1.4-fold (0.14 log units) above the measured one, and the stated range covers the measured number.
By their numbers in this assay, from the lowest: compounds 2, 4 and 1 (each within the scatter of the next, the first and the last beyond it); then compound 3.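

In this assay, the change from phenyl to 4-(trifluoromethyl)phenyl gives a 1.9-fold higher number from compound 2 to compound 4 (0.28 log units; within the scatter), so a group of 4 heavy atoms is accepted at this place without a step that stands clear of the usual scatter. Trading chloro for trifluoromethyl gives a 1.3-fold lower number from compound 1 to compound 4 (0.12 log units; within the scatter), so these two groups cannot be told apart in this cell test, even though removing chloro alone gives a 2.5-fold lower number from compound 1 to compound 2 (0.39 log units; beyond the scatter), a step just beyond the scatter. Both groups tried here also move the number far less than removing the (1-bromoethenyl)carbonyl group, which gives a 610-fold higher number from compound 2 to compound 3 (2.79 log units; beyond the scatter), so the compounds shown depend much more on that group than on what sits on the phenyl ring.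

Nothing measured here explains why the numbers fall as they do. From the compounds shown here alone, it remains open whether a quite different group at this place, such as an amine, a carboxylic acid or a longer chain, would still be accepted or would produce a step well beyond the scatter.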